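The compounds below may be only part of what the source reports. "The series", "measured", "known", "first", "only" and "open" are said of these compounds alone.

Compound 1, `C#CCn1c(=N)sc2cc(OC(F)(F)F)ccc21`, gives in a functional assay on the whole organism with Rattus norvegicus as the target (on this read-out higher numbers stand for an effect only at larger amounts of compound and lower numbers for an effect already at smaller amounts), a value of 4 mg/kg. Compound 2, `N=c1sc2cc(OC(F)(F)F)ccc2n1CC[S+]([O-])c1ccccc1`, gives in this assay a value of 4.2 mg/kg. Among the numbers known so far, compound 2 stands beside compound 1: the two values lie within the usual scatter of each other, so nothing separates them. Compound 3, `CC[S+]([O-])CCn1c(=N)sc2cc(OC(F)(F)F)ccc21`, is the next compound to be measured. Compared with compound 2 it carries ethyl in place of phenyl on a sulfur. Among the measured compounds shown here, no change between two measured compounds has been followed, so there is no measured step to lean on. Because compound 2 gives 4.2 mg/kg and compound 1 gives the similar 4 mg/kg, compound 3 is expected to show a step of a 1.1-fold higher number from compound 2 to compound 3 (0.03 log units; within the scatter) that stays within the scatter, in no particular direction. The estimate for compound 3 in this assay is 4.5 mg/kg, expected to fall between 2 mg/kg and 10 mg/kg.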

Compound 3, dose for half-maximal effect: 1.2 mg/kg
For compound 3 the middle estimate is 3.8-fold (0.57 log units) above the measured one, outside the stated range (below it).
By their numbers in this assay, from the lowest: compound 3; then compounds 1 and 2 (each within the scatter of the next).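

Exchanging phenyl for ethyl on the sulfur gives a 3.5-fold lower number from compound 2 to compound 3 (0.54 log units; beyond the scatter) in this assay, so the group on this sulfur does influence the dose needed, and a six-membered aromatic ring there is not required for an effect at a lower dose. Compounds 1 and 2 alone had shown no difference, but the ethyl-bearing side chain of compound 3 also stands apart from the shorter group of compound 1, with a 3.3-fold lower number from compound 1 to compound 3 (0.52 log units; beyond the scatter) at the saturated chain carbon bound to the aromatic nitrogen. Nothing measured here explains why the ethyl compound needs the smaller dose.

As far as these compounds go, whether a methyl group or a longer chain on the sulfur would lower the number further or raise it again remains open. So does the outcome of replacing this sulfur and its oxygen with an amine.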